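This account rests on a few compounds, and the source may have more. Where it says the series, first, only, none or still open, it means among the compounds named here.

Working notes on the series. In a functional assay on RAW264.7 cells (Mus musculus) for inhibition, read by Griess assay, with stated times of 2 h and 24 h (a lower number here means a stronger inhibitor, a higher number a weaker inhibitor), compound 2 `COc1ccc([C@@H]2CC(=O)c3c(O)cc(OCc4cn(CC5CC5)nn4)cc3O2)cc1O` gives 11900 nM. Going by the values given here, of the two numbers so far, compound 2 holds one and compound 1 `COc1ccc([C@@H]2CC(=O)c3c(O)cc(OCc4cn(Cc5ccc(F)cc5)nn4)cc3O2)cc1O` the other, at 15100 nM, and the step of a 1.3-fold lower number from compound 1 to compound 2 (0.10 log units; within the scatter) lies within the scatter, so the two cannot be told apart in this assay. Compound 3 `COc1ccc([C@@H]2CC(=O)c3c(O)cc(OCc4cn(C5CCC5)nn4)cc3O2)cc1O` is the next member; it differs from compound 2 by cyclobutyl in place of cyclopropylmethyl on an aromatic nitrogen. Among the compounds with values here, the only measured step that bears on this change is the exchange of one group on the same aromatic nitrogen for another, a 1.3-fold lower number from compound 1 to compound 2 (0.10 log units; within the scatter), which was within the scatter. A group of the same atom count, rearranged, at the same place is therefore expected to leave this assay essentially unchanged, with a step of a 1.0-fold higher number from compound 2 to compound 3 (0.00 log units; within the scatter) not beyond the scatter in either direction. For compound 3 the number in this assay is estimated at 12000 nM, with a range of 6000 nM to 24000 nM.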

Compound 3, half-maximal inhibitory concentration: 15300 nM
Estimate against measurement, compound 3: 1.3-fold (0.11 log units) below; the range from low to high includes it.
By their numbers in this assay, from the lowest: compounds 2, 1 and 3 (each within the scatter of the next).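

In this assay, cyclobutyl in place of cyclopropylmethyl on the aromatic nitrogen gives a 1.3-fold higher number from compound 2 to compound 3 (0.11 log units; within the scatter), so rejoining the same carbon atoms into a different ring and chain arrangement at this position is not resolved by this read-out. Cyclobutyl in place of 4-fluorobenzyl gives a 1.0-fold higher number from compound 1 to compound 3 (0.01 log units; within the scatter), which adds a direct comparison and leaves all three groups at this nitrogen indistinguishable, with no compound in the set set apart from the others. Nothing available explains why these groups read alike.

Open, going by these compounds, is whether a group of another kind on this nitrogen, such as an amine, a carboxylic acid or a longer chain, would move the number beyond the scatter. On these data alone, all three compounds share the rest of the core, so the effect of any change outside this position also remains open.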